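Swapping an Acetyl for a Chloro on the Shared Core

A few compounds are considered here, and "the series" means these few. Any claim that something is new, unique, unknown or untested is made for them only; others in the source may bear on it.

Of the compounds shown here, three built on the same core have been measured in an ADME assay on the whole organism with Oryza sativa as the target, tested at 1 uM; a lower number here means a stronger effect, a higher number a weaker effect of the compound at the concentration tested. Compound 1 `Cc1cccc(NC(=O)N[C@H](C)c2ccccc2)c1` gives 98%. Compound 2 `CCc1cccc(NC(=O)N[C@H](C)c2ccccc2)c1` gives 71%, and compound 3 `CC(=O)c1cccc(NC(=O)N[C@H](C)c2ccccc2)c1` gives 88%. Among these three numbers compound 3 stands second highest: the step of a number 10 percentage points lower from compound 1 to compound 3 (within the scatter) lies within the scatter, whereas the step of a number 17 percentage points higher from compound 2 to compound 3 (beyond the scatter) lies beyond it. The largest movement seen so far is a number 27 percentage points lower from compound 1 to compound 2 (beyond the scatter), a modest drop.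

Compound 4 `C[C@@H](NC(=O)Nc1cccc(Cl)c1)c1ccccc1` has not yet been measured. It differs from compound 3 by chloro in place of acetyl on an aromatic carbon. Going by the values given here, no measured step exchanges an acetyl for a chloro, so the expectation rests on neighbouring changes. The step of a number 10 percentage points lower from compound 1 to compound 3 (within the scatter) shows that replacing a methyl by an acetyl on that aromatic carbon stays within the scatter, and the chloro, like that methyl, is a single heavy atom without hydrogen-bond acceptors. Compound 1, which carries the methyl, gives 98%.

For compound 4 the expected step is therefore a number 3 percentage points higher from compound 3 to compound 4 (within the scatter), a small rise that stays within the scatter. Compound 4 is expected to give 91%, with a range from 72% to 100%.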

Compound 4, a percentage reported as activity, at one concentration (the size of the read-out at that concentration, not a potency): 91%
Beside the measured number, compound 4's estimate shows no gap at the digits printed; the range from low to high includes it.
By their numbers in this assay, from the lowest: compound 2; then compounds 3, 4 and 1 (each within the scatter of the next).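

At this position on the aromatic ring, meta to a large group, chloro falls in with methyl and acetyl in this assay: the step of a number 3 percentage points higher from compound 3 to compound 4 (within the scatter) and the step of a number 7 percentage points lower from compound 1 to compound 4 (within the scatter) both stay inside the usual spread of repeat measurements. Going by these compounds alone, this holds even though the exchange replaces acetyl, with 3 heavy atoms and 1 hydrogen-bond acceptor, by chloro, with 1 heavy atom and 0 hydrogen-bond acceptors, so these counts alone do not track the read-out across this pair, while the step of a number 20 percentage points higher from compound 2 to compound 4 (beyond the scatter) leaves ethyl as the only group here that stands apart from the others. No measurement at hand offers an explanation for why ethyl differs from these three groups.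

The compounds shown leave open whether a longer chain such as propyl at this position would go with compound 2 or with the other three compounds, and the same question applies to an amine, a carboxylic acid or a methoxy group. They also leave open whether chloro would give a similar number on a different carbon of this ring.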